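Three Limits, One Methoxy Step Made Twice

This account rests on a few compounds, and the source may have more. Where it says the series, first, only, none or still open, it means among the compounds named here.

Three compounds built on a shared core were tested in a functional assay on Malme-3M cells (Homo sapiens) for cytotoxicity, read by MTT assay, with a stated time of 6 days; a higher number here means that more compound is needed for the effect, a lower number that less compound is needed. Compound 1, `COC(=O)c1c(-c2ccc(OCc3ccccc3)cc2)oc2ccccc2c1=O`, gives in this assay > 25 ug/mL, which is a limit of the measurement rather than a number. Compound 2, `COC(=O)c1c(-c2ccc(OCc3ccccc3)cc2)oc2ccc(OC)cc2c1=O`, differs from compound 1 by methoxy in place of hydrogen on an aromatic carbon, and in this assay compound 2 gives > 25 ug/mL, again a limit. Compound 3, `COC(=O)c1c(-c2ccc(O)cc2)oc2ccccc2c1=O`, differs from compound 1 by hydrogen in place of benzyl on an oxygen on an aromatic ring, and in this assay compound 3 gives > 25 ug/mL, also a limit. The steps a step that the two limits leave unreadable from compound 1 to compound 2 and a step that the two limits leave unreadable from compound 1 to compound 3 therefore cannot be sized, because every value shown sits at the limit of > 25 ug/mL in this assay, at which 3 of the 3 values shown sit.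

Compound 4, `COC(=O)c1c(-c2ccc(O)cc2)oc2cc(OC)ccc2c1=O`, has not yet been measured. It differs from compound 3 by methoxy in place of hydrogen on an aromatic carbon. The place described for this change reads word for word the same as for the change from compound 1 to compound 2, so it is the same structural change, made a second time on a core in which benzyloxy has become hydroxy.

The step that the limit leaves unreadable from compound 3 to compound 4 is expected to be unreadable or small, an expectation that rests on every measured value standing at the limit of > 25 ug/mL in this assay, at which 3 of the 3 values shown sit. The estimate for compound 4 in this assay is 35 ug/mL, with a range from 15 ug/mL to 90 ug/mL, and it is expected that the assay will most likely again report only a limit.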

Compound 4, concentration for half-maximal effect: 20.1 ug/mL
Estimate against measurement, compound 4: 1.7-fold (0.24 log units) above; the measured number falls inside the stated range.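

In this assay, the methoxy change gives an at least 1.2-fold lower number from compound 3 to compound 4 (0.09 log units; that floor lies within the scatter). For the compounds shown here, compound 3 stands only at a limit, so the true step could be larger, but the part that can be read does not go beyond ordinary scatter, and this result shows only that compound 4 gives a number where the other compounds give limits, not that methoxy truly lowers the number on this core. It also does not show that the change carries from one core to another, since the step from compound 1 to compound 2 cannot be read and the two steps cannot be compared in size, and the structures place the methoxy on different ring carbons in compound 2 and compound 4, so this is not strictly one change made twice; the only reading available for the other measured compounds is this: the limit of > 25 ug/mL in this assay, at which 3 of the 4 values shown sit.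

The compounds shown leave open whether compound 4's methoxy position would also give a number on the core that carries benzyloxy, and how far below the limit compound 3 might lie. They also leave open what an amine, a carboxylic acid or a longer chain such as butoxy at that same ring carbon would do.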